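Ethoxy to trifluoromethyl on the shared core

The compounds below may be only part of what the source reports. "The series", "measured", "known", "first", "only" and "open" are said of these compounds alone.

In a functional assay on Hep 3B2 cells (Homo sapiens) for antiproliferative activity, read by MTT assay, with a stated time of 24 h (on this read-out lower numbers stand for stronger inhibition and higher numbers for weaker inhibition), compound 1 (`Cc1ccc2nc(C(=O)Nc3c(F)cc(-c4cccc(F)c4)cc3F)c(C)c(C(=O)O)c2c1`) gives 31600 nM and compound 2 (`CCOc1ccc2nc(C(=O)Nc3c(F)cc(-c4cccc(F)c4)cc3F)c(C)c(C(=O)O)c2c1`) gives 5800 nM. For the measured compounds named here, compound 2 therefore holds the lower of the two numbers so far. Compound 3 (`Cc1c(C(=O)Nc2c(F)cc(-c3cccc(F)c3)cc2F)nc2ccc(C(F)(F)F)cc2c1C(=O)O`) carries trifluoromethyl in place of ethoxy on an aromatic carbon. Going by the values given here, only one measured step bears on this carbon, a 5.4-fold lower number from compound 1 to compound 2 (0.74 log units; beyond the scatter), a modest change beyond the scatter. Among the compounds with values here, it shows that ethoxy gives a lower number than methyl, but no measured compound yet carries trifluoromethyl, so the direction rests on this single comparison. Loss of ethoxy is expected to move the number upward in this assay, by a step of modest size. The expected step is a 2.4-fold higher number from compound 2 to compound 3 (0.38 log units; beyond the scatter). For compound 3 the estimated value is 14000 nM, with an expected range of 4500 nM to 40000 nM.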

Compound 3, half-maximal inhibitory concentration: 7570 nM
Beside the measured number, compound 3's estimate is 1.8-fold (0.27 log units) above it; the range from low to high includes it.
By their numbers in this assay, from the lowest: compounds 2 and 3 (each within the scatter of the next); then compound 1.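

In this assay the exchange of ethoxy for trifluoromethyl on this aromatic carbon leaves the two groups indistinguishable (a 1.3-fold higher number from compound 2 to compound 3 (0.12 log units; within the scatter)), so the lower number relative to methyl is not confined to ethoxy. Trifluoromethyl also reads clear of methyl (a 4.2-fold lower number from compound 1 to compound 3 (0.62 log units; beyond the scatter)), although trifluoromethyl carries no hydrogen-bond acceptor and ethoxy carries one, so an acceptor in the group is not needed for this step in the compounds shown. No measurement at hand explains why these two groups read alike.

On these data alone, it remains open whether an amine, a hydroxyl or a longer alkoxy chain at this carbon would follow ethoxy and trifluoromethyl or fall back towards methyl. Whether a bare hydrogen or a single chlorine would read with methyl is equally unsettled.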